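Series notes: amide aryl replacement on the shared core

The source may report more compounds than this note shows. Statements on the series, on what has been measured and on what is new or still open speak of the compounds shown alone.

Measured so far in a physicochemical assay for lipophilicity, read by HPLC, in phosphate buffer, measured as chromatographic lipophilicity, at pH 7.4; a lower number here means a more polar compound, a higher number a more lipophilic compound:
compound 1, `COc1ccc2nc(C)cc(OCC(=O)Nc3cc(C)cc(C)c3)c2c1`: 5.64
compound 2, `Cc1cc(C)cc(NC(=O)COc2cc(C)nc3ccccc23)c1`: 5.39
compound 3, `CCC(Oc1cc(C)nc2ccc(OC)cc12)C(=O)Nc1cc(C)cc(C)c1`: 6.28

Compound 1 sits between the other two: against compound 2 the step is a number 0.25 log units lower from compound 1 to compound 2 (within the scatter), while against compound 3 it is a number 0.64 log units higher from compound 1 to compound 3 (beyond the scatter). The next compound is compound 4, `COc1ccc2nc(C)cc(OCC(=O)Nc3nccs3)c2c1`. Its difference from compound 1 is 1,3-thiazol-2-yl in place of 3,5-dimethylphenyl on an amide-type nitrogen. Neither measured step touches this position; the change from compound 1 to compound 2 alters a substituent on an aromatic carbon of the core, and that to compound 3 alters the chain carbon. Within the data shown here, no measured step therefore bears directly on it. From the group counts alone, a step in this assay toward a more polar compound is expected, larger than the two steps seen so far. For compound 4 the estimate is 3.6, range 2.9 to 4.3, meaning an expected step of a number 2.04 log units lower from compound 1 to compound 4 (beyond the scatter).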

Compound 4, distribution coefficient: 3.2
Beside the measured number, compound 4's estimate is 0.40 log units above it; low and high end bracket the measured number.
By their numbers in this assay, from the lowest: compound 4; then compounds 2 and 1 (each within the scatter of the next); then compound 3.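

In this assay, among these compounds, the amide-type nitrogen carries the largest single-place change so far (a number 2.44 log units lower from compound 1 to compound 4 (beyond the scatter)), exceeding both earlier steps at the aromatic carbon and the chain carbon. The change replaces 3,5-dimethylphenyl, with 8 heavy atoms and 0 hydrogen-bond acceptors, with 1,3-thiazol-2-yl, with 5 heavy atoms and 2 hydrogen-bond acceptors. Nothing available explains the size of this step.

Still open, from the compounds shown here alone, is how the step divides among the methyl groups, ring size and ring hetero atoms. Unsubstituted phenyl or pyridin-2-yl on the same nitrogen would help separate these contributions.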